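Moving from ureido to a free acid chain on the sulfone-bearing ring

The source may report more compounds than this note shows. Statements on the series, on what has been measured and on what is new or still open speak of the compounds shown alone.

Of the compounds shown here, three sharing one core have been measured in a functional assay on HEL cells (Homo sapiens); a lower number here means that less compound is tolerated, a higher number that more compound is tolerated. Compound 1 `Cc1cn([C@@H]2O[C@H](CO[Si](C)(C)C(C)(C)C)[C@@]3(OS(=O)(=O)C=C3NCCC(=O)OCc3ccccc3)[C@H]2O[Si](C)(C)C(C)(C)C)c(=O)n(C)c1=O` gives 200000 nM, while compound 2 `Cc1cn([C@@H]2O[C@H](CO[Si](C)(C)C(C)(C)C)[C@@]3(OS(=O)(=O)C=C3NC(=O)c3ccccc3)[C@H]2O[Si](C)(C)C(C)(C)C)c(=O)n(C)c1=O` gives 9700 nM and compound 3 `Cc1cn([C@@H]2O[C@H](CO[Si](C)(C)C(C)(C)C)[C@@]3(OS(=O)(=O)C=C3NC(N)=O)[C@H]2O[Si](C)(C)C(C)(C)C)c(=O)n(C)c1=O` gives 11000 nM. Compound 3 stands second highest of the three, with compound 2 within the scatter of it and compound 1 far above it: a 1.1-fold higher number from compound 2 to compound 3 (0.05 log units; within the scatter), an 18-fold lower number from compound 1 to compound 3 (1.26 log units; beyond the scatter).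

Compound 4 `Cc1cn([C@@H]2O[C@H](CO[Si](C)(C)C(C)(C)C)[C@@]3(OS(=O)(=O)C=C3NCCC(=O)O)[C@H]2O[Si](C)(C)C(C)(C)C)c(=O)n(C)c1=O` differs from compound 3 in one place: 2-carboxyethyl in place of carbamoyl on an amine nitrogen.

Among the compounds with values here, no measured step exchanges carbamoyl for 2-carboxyethyl directly. The closest guidance is that compound 1, which carries the related 2-(benzyloxycarbonyl)ethyl chain on the same amine nitrogen, tolerated far more compound than both the benzoyl and the carbamoyl analogues: a 21-fold lower number from compound 1 to compound 2 (1.31 log units; beyond the scatter) and an 18-fold lower number from compound 1 to compound 3 (1.26 log units; beyond the scatter). Since compound 4 returns to a three-carbon chain ending in a carbonyl, a large step back toward the number of compound 1 is expected, though the free acid rather than the benzyl ester adds uncertainty, so the expected step is a 9.1-fold higher number from compound 3 to compound 4 (0.96 log units; beyond the scatter). Compound 4 is therefore estimated at 100000 nM, with a range from 20000 nM to 400000 nM.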

Compound 4, half-maximal cytotoxic concentration: 34000 nM
Beside the measured number, compound 4's estimate is 2.9-fold (0.47 log units) above it, and the stated range covers the measured number.
By their numbers in this assay, from the lowest: compounds 2 and 3 (each within the scatter of the next); then compound 4; then compound 1.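

In this assay, the 2-carboxyethyl chain on the amine nitrogen separates from both acylated analogues, with a 3.1-fold higher number from compound 3 to compound 4 (0.49 log units; beyond the scatter) and a 3.5-fold higher number from compound 2 to compound 4 (0.54 log units; beyond the scatter), so this position responds to more than the gap already seen between compounds 2 and 3 and compound 1. Replacing benzyl with hydrogen on the oxygen next to the carbonyl group gives a 5.9-fold lower number from compound 1 to compound 4 (0.77 log units; beyond the scatter), which shows that the benzyl ester and the free carboxylic acid on the same chain are not equivalent here, and that the chain without its benzyl group accounts for only part of the high number of compound 1. Nothing available explains why either change moves the number as it does.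

Going by these compounds, how much depends on the length of the chain remains open, and a carboxymethyl group or a longer 3-carboxypropyl chain on the same nitrogen would test this. Whether the carboxylic acid itself matters is also unsettled, and a methyl ester, a primary amide or a plain propyl chain in its place would help separate the acid from the carbon chain that carries it.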